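Working notes: from compound 1 to compound 4

The source may report more compounds than this note shows. Statements on the series, on what has been measured and on what is new or still open speak of the compounds shown alone.

In an ADME assay for permeability, using PAMPA, in phosphate buffer, with a stated time of 18 h, tested at 25 ug/mL (on this read-out lower numbers stand for lower permeability and higher numbers for higher permeability), compound 1 (`O=C(N/N=C/c1ccc(Br)cc1)N1CCN(c2ccccn2)CC1`) gives 3.6 10^-6 cm/s as its reading. In this assay compound 2 (`FC(F)(F)Oc1ccc(-c2nnc(N3CCN(c4ccccn4)CC3)o2)cc1`) gives 6.8 10^-6 cm/s and compound 3 (`Brc1ccc(-c2nnc(N3CCN(c4ccccn4)CC3)o2)cc1`) gives 5.9 10^-6 cm/s on the same scale. Compound 1 stands within the scatter of both, and no order among the three is drawn.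

Compound 4 (`O=C(N/N=C/c1ccc(F)cc1F)N1CCN(c2ccccn2)CC1`) has not yet been measured. It differs from compound 1 by a single exchange (2,4-difluorophenyl in place of 4-bromophenyl on a carbon with a double bond to nitrogen): 2,4-difluorophenyl in place of 4-bromophenyl on a carbon with a double bond to nitrogen.

Among the compounds with values here, only one measured step offers any guide (a 1.2-fold lower number from compound 2 to compound 3 (0.06 log units; within the scatter)), with bromo in place of trifluoromethoxy on an aromatic carbon. It lies within the scatter, but it belongs to the core shared by compound 2 and compound 3, not to the core of compound 1. Within the data shown here, no measured compound carries the 2,4-difluorophenyl group, so the guide is indirect. On this evidence no step beyond the scatter is expected in this assay and no direction is relied on. The estimated step is a 1.1-fold higher number from compound 1 to compound 4 (0.02 log units; within the scatter) and it is expected to stay within the scatter. In this assay the estimated value for compound 4 is 3.8 10^-6 cm/s with the reading expected to fall between 2 10^-6 cm/s and 7 10^-6 cm/s around it.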

Compound 4, apparent permeability: 4.1 10^-6 cm/s
The estimate for compound 4 lay 1.1-fold (0.03 log units) below the measured number; measured number inside the range.
By their numbers in this assay, from the lowest: compounds 1, 4, 3 and 2 (each within the scatter of the next).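

Within the data shown here, on the core of compound 1, the only exchange read at this position, on a carbon with a double bond to nitrogen, gives a 1.1-fold higher number from compound 1 to compound 4 (0.06 log units; within the scatter) in this assay. Among these compounds, the only step available before this one, a 1.2-fold lower number from compound 2 to compound 3 (0.06 log units; within the scatter), lay on a different core, so this is the first direct reading for this position: replacing 4-bromophenyl with 2,4-difluorophenyl, which keeps a six-membered aromatic ring of carbon only and adds no counted hydrogen-bond donor or acceptor, produces no step beyond the scatter. No measurement in hand gives a reason for this reading.

From the compounds shown here alone, whether an amine, a carboxylic acid or a longer alkyl chain on a carbon with a double bond to nitrogen would produce a step beyond the scatter in this assay remains open. Among the compounds shown here, also open is whether 2,4-difluorophenyl would read the same way on the core shared by compound 2 and compound 3, as the single step here cannot be carried from one core to the other.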